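This account rests on a few compounds, and the source may have more. Where it says the series, first, only, none or still open, it means among the compounds named here.

Compound 3 `CCC(CO[C@H](CC=C(C)C)C1=CC(=O)c2c(O)ccc(O)c2C1=O)OC(C)=O` is one of three compounds tested in a functional assay on HeLa cells (Homo sapiens) for cytotoxicity, read by MTT assay; a higher number here means a weaker inhibitor, a lower number a stronger inhibitor. In this assay compound 3 gives 44000 nM, the second highest of the three numbers. Its nearest neighbour is compound 1 `CC(C)=CC[C@@H](OC(=O)c1ccco1)C1=CC(=O)c2c(O)ccc(O)c2C1=O`, which in this assay gives 80300 nM; the two lie within the scatter of each other. Compound 2 `CC(C)=CC[C@@H](OC[C@@H](C)O)C1=CC(=O)c2c(O)ccc(O)c2C1=O` in this assay gives 22500 nM, and the step from compound 1 to compound 2 is a 3.6-fold lower number from compound 1 to compound 2 (0.55 log units; beyond the scatter), while the step from compound 2 to compound 3 is a 2.0-fold higher number from compound 2 to compound 3 (0.29 log units; within the scatter). Compound 4 `CC(C)=CC[C@@H](OC(=O)c1ccoc1)C1=CC(=O)c2c(O)ccc(O)c2C1=O` differs from compound 3 in one place: (furan-3-yl)carbonyl in place of 2-acetoxybutyl on an oxygen on a saturated carbon. The step that bears most directly on this change runs the other way, from compound 1 to compound 3, where a (furan-2-yl)carbonyl gave way to a 2-acetoxybutyl and produced a 1.8-fold lower number from compound 1 to compound 3 (0.26 log units; within the scatter). Returning to a furan carbonyl, now the (furan-3-yl)carbonyl, is therefore expected to move the number only slightly upward, as a 1.6-fold higher number from compound 3 to compound 4 (0.20 log units; within the scatter). The value for compound 4 in this assay is estimated at 70000 nM, within 30000 nM to 160000 nM.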

Compound 4, half-maximal inhibitory concentration: > 100000 nM
Compound 4 gave a limit, no number; the forecaster's own chance of this, stated with the estimate: 10%; middle value at least 1.4-fold (0.15 log units) away from the limit.
By their numbers in this assay, from the lowest: compounds 2, 3 and 1 (each within the scatter of the next, the first and the last beyond it). At a limit, above all of these: compound 4.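

Compound 4 gives no number in this assay, only a limit: the limit of > 100000 nM in this assay, at which 1 of the 4 values shown sits. Among the compounds shown here, exchanging 2-acetoxybutyl for (furan-3-yl)carbonyl on this oxygen gives an at least 2.2-fold higher number from compound 3 to compound 4 (0.35 log units; beyond the scatter), and exchanging 2-hydroxypropyl for it gives an at least 4.4-fold higher number from compound 2 to compound 4 (0.64 log units; beyond the scatter), so a furan carbonyl now stands clearly apart from both chains, whereas the earlier compounds showed this only against 2-hydroxypropyl. Moving the furan attachment gives an at least 1.2-fold higher number from compound 1 to compound 4 (0.09 log units; that floor lies within the scatter), a floor that does not separate furan-3-yl from furan-2-yl on the carbonyl carbon.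

On these data alone, how far compound 4 lies beyond its limit remains open, and with it whether the furan attachment matters at all. Also open, as far as these compounds go, is how a benzoyl group or a chain ending in an amine would read on this oxygen.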